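From chloro to isopropoxy on an aromatic carbon

The source may report more compounds than this note shows. Statements on the series, on what has been measured and on what is new or still open speak of the compounds shown alone.

Measured in an ADME assay on KB cells (Homo sapiens) for cytotoxicity, read by MTT assay, with a stated time of 72 h; on this read-out higher numbers stand for weaker inhibition and lower numbers for stronger inhibition:
Compound 1 `COc1ccc(C2=C(c3cc(OC)c(OC)c(OC)c3)C(=O)C(O)C2)cc1NC(=O)c1ccccc1` reads > 100 ug/mL, a limit and not a number
Compound 2 `COc1ccc(C2=C(c3cc(OC)c(OC)c(OC)c3)C(=O)C(O)C2)cc1Cl` reads 2.5 ug/mL

Among the measured compounds shown here, compound 2 stands at 2.5 ug/mL, the only actual number in this small set. The next compound to be tested is compound 3 `COc1ccc(C2=C(c3cc(OC)c(OC)c(OC)c3)C(=O)C(O)C2)cc1OC(C)C`, which differs from compound 2 as follows: isopropoxy in place of chloro on an aromatic carbon. The new group sits on the same aromatic carbon, ortho to a methoxy group and meta to a large group.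

For the measured compounds named here, one measured step bears on this place: an at least 40-fold lower number from compound 1 to compound 2 (1.60 log units; beyond the scatter), large and beyond the scatter. Isopropoxy is neither of the two groups in that step, so the step shows only that a change here can matter greatly. A moderate step towards weaker inhibition, smaller than that one, seems likely. The expected step is a 3.2-fold higher number from compound 2 to compound 3 (0.51 log units; beyond the scatter). For compound 3 the estimate is 8 ug/mL, with an expected range of 1.5 ug/mL to 50 ug/mL.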

Compound 3, half-maximal inhibitory concentration: > 100 ug/mL
Compound 3 ended at the assay's limit; the forecaster's own chance of this, stated with the estimate: 15%; middle value at least 12-fold (1.09 log units) away from the limit.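

In this assay, among the compounds shown here, isopropoxy in place of chloro on this aromatic carbon gives an at least 40-fold higher number from compound 2 to compound 3 (1.60 log units; beyond the scatter), so benzamido is no longer the only group here that goes with a large loss. Among the three groups shown at this place, ortho to a methoxy group, only chloro gives a readable number, and the earlier pair could not show that a much smaller group than benzamido, with 4 heavy atoms, would also reach the limit. The step between compound 1 and compound 3 cannot be read, and the two compounds cannot be ranked: the limit of > 100 ug/mL in this assay, at which 2 of the 3 values shown sit.

Still open, from the compounds shown here alone, is whether a small group such as fluoro, methyl or hydroxyl on this carbon would stay close to compound 2 or fall away as well. An amine here is equally untested by the compounds shown, so it remains unclear whether chloro is a lone exception at this place.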